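Trifluoromethoxy for Cyclopropylsulfonyl on a Sulfonamide Aryl Ring

A few compounds are considered here, and "the series" means these few. Any claim that something is new, unique, unknown or untested is made for them only; others in the source may bear on it.

Of the compounds shown here, three sharing a common core have been measured in an assay for inhibition of Apoptosis regulator Bcl-2 (Homo sapiens), read by fluorescence polarization, with a stated time of 2 h; on this read-out lower numbers stand for stronger inhibition and higher numbers for weaker inhibition. Compound 1 `CCCn1c(C)c(C(=O)O)c(-c2cccc(N3CCN(c4ccc(NS(=O)(=O)c5ccc(N[C@H](CCN6CCC(O)CC6)CSc6ccccc6)c(S(=O)(=O)C(F)(F)F)c5)cc4)CC3)c2)c1-c1ccc(Cl)cc1` gives 30.1 nM in this assay, and compound 2 `Cc1c(C(=O)O)c(-c2cccc(N3CCN(c4ccc(NS(=O)(=O)c5ccc(N[C@H](CCN6CC(O)C6)CSc6ccccc6)c(S(=O)(=O)C(F)(F)F)c5)cc4)CC3)c2)c(-c2ccc(Cl)cc2)n1C` gives 7.7 nM. Compound 3 `Cc1c(C(=O)NCCCN2CCN(C)CC2)c(-c2cccc(N3CCN(c4ccc(NS(=O)(=O)c5cccc(S(=O)(=O)C6CC6)c5)cc4)CC3)c2)c(-c2ccc(Cl)cc2)n1C` gives 844 nM, the highest number of the three; its gaps to compound 1 and to compound 2 both lie beyond the usual scatter of this read-out, so compound 3 is the weakest inhibitor of the three shown.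

Compound 4 `Cc1c(C(=O)NCCCN2CCN(C)CC2)c(-c2cccc(N3CCN(c4ccc(NS(=O)(=O)c5cccc(OC(F)(F)F)c5)cc4)CC3)c2)c(-c2ccc(Cl)cc2)n1C` has not yet been measured. It differs from compound 3 in one place: trifluoromethoxy in place of cyclopropylsulfonyl on an aromatic carbon. For the measured compounds named here, no pair of measured compounds differs in this single place, so no measured step describes this change on its own; compound 1 and compound 2 differ from compound 3 in several places at once and say nothing about it by itself. With nothing to lean on, the expected step is a 1.2-fold higher number from compound 3 to compound 4 (0.07 log units; within the scatter), no more than the usual scatter in either direction. Compound 4 is accordingly expected to give 1000 nM in this assay, with a range from 300 nM to 4000 nM.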

Compound 4, half-maximal inhibitory concentration: 763 nM
Estimate against measurement, compound 4: 1.3-fold (0.12 log units) above; the range from low to high includes it.
By their numbers in this assay, from the lowest: compound 2; then compound 1; then compounds 4 and 3 (each within the scatter of the next).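

In this assay, trifluoromethoxy in place of cyclopropylsulfonyl on this aromatic carbon amounts to a 1.1-fold lower number from compound 3 to compound 4 (0.04 log units; within the scatter), so this read-out does not tell the two compounds apart. The group that leaves carries a three-membered carbon ring and two double bonds, and the group that enters has no ring, yet in this pair that exchange, meta to a large group, leaves no difference beyond the scatter. Nothing measured here offers an explanation for this result. The compounds shown leave open whether a nitrile, a methoxy group or a simple amine on the same carbon would also fall within the scatter of compound 3. They also leave open whether this exchange would read the same on a core carrying a carboxylic acid in place of the amide chain.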